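Amide nitrogen substituent variation: expectation for compound 4

The compounds below may be only part of what the source reports. "The series", "measured", "known", "first", "only" and "open" are said of these compounds alone.

Compound 2 `COc1cc(-c2cc(C(=O)O)c3ccccc3n2)ccc1OCC(=O)Nc1ccccc1F` gives 161000 nM in an ADME assay on HaCaT cells (Homo sapiens) for inhibition; a lower number here means a stronger inhibitor, a higher number a weaker inhibitor. Among the three measured members it stands second highest; compound 1 `COc1cc(-c2cc(C(=O)O)c3ccccc3n2)ccc1OCC(=O)Nc1ccccc1C` gives 230000 nM and compound 3 `COc1cc(-c2cc(C(=O)O)c3ccccc3n2)ccc1OCC(=O)Nc1cccc(C(F)(F)F)c1` gives 160000 nM, and the steps of a 1.4-fold lower number from compound 1 to compound 2 (0.15 log units; within the scatter) and a 1.0-fold lower number from compound 2 to compound 3 (0.00 log units; within the scatter) both lie within the scatter, so no order is claimed among the three.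

Compound 4 `COc1cc(-c2cc(C(=O)O)c3ccccc3n2)ccc1OCC(=O)NCc1ccccc1` differs from compound 2 in one place: benzyl in place of 2-fluorophenyl on an amide-type nitrogen. Among the measured compounds shown here, no measured step exchanges an aryl group for a benzyl group on this nitrogen. For the measured compounds named here, the steps that bear on the change are those altering the group on the same amide-type nitrogen: a 1.4-fold lower number from compound 1 to compound 2 (0.15 log units; within the scatter), a 1.4-fold lower number from compound 1 to compound 3 (0.16 log units; within the scatter) and a 1.0-fold lower number from compound 2 to compound 3 (0.00 log units; within the scatter), each within the scatter. Three different groups on this nitrogen have left the number unchanged within the scatter, so a fourth is expected to do the same, with no step beyond the scatter expected in this assay. The expected step is a 1.1-fold higher number from compound 2 to compound 4 (0.02 log units; within the scatter). Compound 4 is therefore estimated at 170000 nM, with a range from 80000 nM to 350000 nM.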

Compound 4, half-maximal inhibitory concentration: > 300000 nM
Compound 4: no number, only a limit; the forecaster's own chance of this, stated with the estimate: 15%; middle value at least 1.7-fold (0.24 log units) away from the limit.
By their numbers in this assay, from the lowest: compounds 3, 2 and 1 (each within the scatter of the next). At a limit, above all of these: compound 4.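

In this assay, among the compounds shown here, compound 4, with benzyl on the amide-type nitrogen, is the first member to give a limit of the assay instead of a number: the limit of > 300000 nM in this assay, at which 1 of the 4 values shown sits.
Against the aryl groups, the exchange for benzyl gives an at least 1.8-fold higher number from compound 2 to compound 4 (0.27 log units; that floor lies within the scatter) and an at least 1.8-fold higher number from compound 3 to compound 4 (0.27 log units; that floor lies within the scatter) and also an at least 1.3-fold higher number from compound 1 to compound 4 (0.11 log units; that floor lies within the scatter) as the only readable steps.
Going by these compounds, each floor lies within the scatter, so benzyl cannot yet be told apart from the three aryl groups on this nitrogen, and the true size of each step stays unknown.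

Open, on these data alone, is whether a longer chain such as phenethyl, or an aminoalkyl group, on this nitrogen would give a number or another limit. Also open, as far as these compounds go, is what an ester in place of the carboxylic acid of the shared core would do in this assay to these values.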